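The source may hold more compounds than are shown below. What is called first, only, known or untested is meant among the compounds shown, and "the series" means these compounds.

In an ADME assay on HEK293 cells (Homo sapiens) for inhibition, read by MTT assay, with a stated time of 96 h; a higher number here means a weaker inhibitor of growth, a lower number a stronger inhibitor of growth:
- compound 1 `O=C(OCc1ccccc1)SCCCCCCNC(=O)c1cc(-c2ccncc2)n[nH]1`: 19700 nM
- compound 2 `CCCC(=O)SCCCCCCNC(=O)c1cc(-c2ccncc2)n[nH]1`: > 50000 nM

Compound 2 gives > 50000 nM, which is a limit of the assay and not a number. Compound 2 thus stands at the limit of > 50000 nM in this assay, at which 1 of the 2 values shown sits.

Compound 3 `CCC(=O)SCCCCCCNC(=O)c1cc(-c2ccncc2)n[nH]1` has not yet been measured. It differs from compound 2 by hydrogen in place of methyl on a saturated chain carbon, two bonds along the chain from a carbonyl carbon. Propyl on the carbonyl carbon thereby becomes ethyl.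

Going by the values given here, only one measured step bears on this: an at least 2.5-fold higher number from compound 1 to compound 2 (0.40 log units; beyond the scatter). It concerns the same carbonyl carbon, but it exchanged a whole benzyloxy group, whereas here a single methyl leaves. A step beyond the scatter is therefore not expected in this assay, and no direction can be favoured. The estimate amounts to a number no higher from compound 2 to compound 3 (the limit leaves the size open), as expected from this comparison. Compound 3 is expected at 50000 nM, with an estimated range of 25000 nM to 100000 nM.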

Compound 3, concentration for 50% growth inhibition: > 50000 nM
Compound 3: a limit, no number; the forecaster's own chance of this, stated with the estimate: 60%; the middle value lies on the limit itself.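

In this assay, compound 3 gives > 50000 nM, which is a limit of the assay and not a number. The step from compound 2 to compound 3 cannot be read, as both values are limits, so removing this methyl shows no measurable growth inhibition returning. Ethyl in place of benzyloxy on the carbonyl carbon gives an at least 2.5-fold higher number from compound 1 to compound 3 (0.40 log units; beyond the scatter), so compound 1 is still the only one of the three with a number, and the limit is now shared: the limit of > 50000 nM in this assay, at which 2 of the 3 values shown sit.

On these data alone, how far compound 2 and compound 3 actually lie from each other remains open. So does whether ethoxy or a longer chain such as hexyl on the same carbonyl carbon would give a number within the range of this assay.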